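The compounds below may be only part of what the source reports. "The series", "measured", "known", "first", "only" and "open" are said of these compounds alone.

The measured compounds and their values:

Compound 1, `OC[C@H]1O[C@@H](n2cnc3c(NCc4cccc(F)c4)ncnc32)[C@H](O)[C@@H]1O`, in a functional assay on G-361 cells (Homo sapiens) for antiproliferative activity, with a stated time of 72 h (on this read-out higher numbers stand for weaker inhibition and lower numbers for stronger inhibition), gives > 166000 nM, which is a limit of the assay and not a number.
Compound 2, `OC[C@H]1O[C@@H](n2cnc3c(NCc4ccc(F)cc4)ncnc32)[C@H](O)[C@@H]1O`, in this assay gives > 166000 nM, again a limit of the assay.
Compound 3, `OC[C@H]1O[C@@H](n2cnc3c(NCc4ccccc4Cl)ncnc32)[C@H](O)[C@@H]1O`, in this assay gives "not determined" (no result reported), that is, no result is reported for it.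

For the measured compounds named here, compound 2 therefore stands at a limit rather than at a measured number; the one other value shown is also a limit, and the remaining entry has no number at all, so compound 2 cannot be placed relative to anything. Going by the values given here, the single step that can be drawn, a step that the two limits leave unreadable from compound 1 to compound 2, bears only indirectly on the change now considered and has no readable size, as both of its ends sit at the limit described by the limit of > 166000 nM in this assay, at which 2 of the 3 values shown sit.

The unmeasured compound 4, `OC[C@H]1O[C@@H](n2cnc3c(NCc4ccc(Cl)cc4)ncnc32)[C@H](O)[C@@H]1O`, differs from compound 2 by chloro in place of fluoro on an aromatic carbon. Among the compounds with values here, no measured step shows how a change of this kind moves this assay, and the one related comparison is unreadable. The step from compound 2 to compound 4 is therefore expected to be a number no higher from compound 2 to compound 4 (the limit leaves the size open), with no direction justified beyond the scatter. Compound 4 is accordingly expected to give about 166000 nM, within 40000 nM to 600000 nM, most likely again reported as a limit.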

Compound 4, half-maximal inhibitory concentration: > 166000 nM
Compound 4: only a limit was reported; the forecaster's own chance of this, stated with the estimate: 80%; the middle value sits exactly at the limit.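

In this assay compound 4 gives > 166000 nM, which is a limit of the assay and not a number. No new step can be read from compound 1 or compound 2 to compound 4, because all three stand at the same limit: the limit of > 166000 nM in this assay, at which 3 of the 4 values shown sit.

The compounds shown leave open whether any change on the shared core gives a measured number in this assay.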